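The source may report more compounds than this note shows. Statements on the series, on what has been measured and on what is new or still open speak of the compounds shown alone.

Compound 2 `CCCN1CC(=O)N(Cc2ccc(C(=O)NO)cc2)C1=O` stands second highest of the three numbers in an assay on isolated protein for inhibition of protein deacetylase HDAC6 (Homo sapiens), read by fluorescence, with stated times of 10 min and 2 h (a lower number here means a stronger inhibitor, a higher number a weaker inhibitor), with 53.4 nM, while compound 1 `CN1CC(=O)N(Cc2ccc(C(=O)NO)cc2)C1=O` gives 119 nM in this assay and compound 3 `O=C(NO)c1ccc(CN2C(=O)CN(Cc3ccccc3)C2=O)cc1` gives 12.5 nM in this assay. The change to compound 4 `O=C(NO)c1ccc(CN2C(=O)CN(Cc3ccc(Cl)cc3)C2=O)cc1` is 4-chlorophenyl in place of ethyl on a saturated chain carbon bound to an amide-type nitrogen in a ring. The step that bears most directly on it is a 4.3-fold lower number from compound 2 to compound 3 (0.63 log units; beyond the scatter), which put a phenyl where compound 4 carries a 4-chlorophenyl; the same direction appears in a 9.5-fold lower number from compound 1 to compound 3 (0.98 log units; beyond the scatter) and, more modestly, in a 2.2-fold lower number from compound 1 to compound 2 (0.35 log units; beyond the scatter). A step of similar size toward a lower number is therefore expected in this assay, with compound 4 expected to land close to compound 3. Compound 4 is estimated at 10 nM, in a range from 4 nM to 25 nM, an expected step of a 5.3-fold lower number from compound 2 to compound 4 (0.73 log units; beyond the scatter).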

Compound 4, half-maximal inhibitory concentration: 8.3 nM
For compound 4 the middle estimate is 1.2-fold (0.08 log units) above the measured one; the measured number falls inside the stated range.
By their numbers in this assay, from the lowest: compounds 4 and 3 (each within the scatter of the next); then compound 2; then compound 1.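

In this assay, this position takes a substituted phenyl as well as a plain one: a 1.5-fold lower number from compound 3 to compound 4 (0.18 log units; within the scatter) is the chloro step, so compound 3 and compound 4 cannot be told apart. Among these compounds, the advantage over the smaller groups persists with the 4-chlorophenyl, as a 6.4-fold lower number from compound 2 to compound 4 (0.81 log units; beyond the scatter) and a 14-fold lower number from compound 1 to compound 4 (1.16 log units; beyond the scatter) show, the latter being the only step here printed as large. From the compounds shown here alone, whether an amine or a carboxylic acid in place of the chloro, or a longer chain carrying the phenyl, would hold this level stays open. Nothing given here explains these steps.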